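The source may report more compounds than this note shows. Statements on the series, on what has been measured and on what is new or still open speak of the compounds shown alone.

Measured so far:
compound 1, `O=C(Nc1ccc(-c2cscn2)cc1)C1CCN(Cc2ccc(F)c(F)c2)CC1`: 19000 nM
compound 2, `O=C(Nc1ccc(-c2cccnc2)cc1)C1CCCN(Cc2ccc(F)c(F)c2)C1`: 1060 nM

Both were tested in a functional assay on A-375 cells (Homo sapiens) for activation, with a stated time of 3 days; a higher number here means that more compound is needed for the effect, a lower number that less compound is needed. Compound 2 has the lowest of the two numbers; compound 1 needs clearly more compound, a gap well beyond the usual scatter. Compound 3, `O=C(Nc1ccc(-c2cccs2)cc1)C1CCCN(Cc2ccc(F)c(F)c2)C1`, has not yet been measured. It differs from compound 2 in one place: thiophen-2-yl in place of pyridin-3-yl on an aromatic carbon. Among the measured compounds shown here, no measured pair shows this exact change, so the expectation rests on compound 2 alone. A modest rise in the number is expected, possibly no larger than the scatter. Compound 3 is expected to give about 2000 nM, within 500 nM to 8000 nM. That estimate means an expected step of a 1.9-fold higher number from compound 2 to compound 3 (0.28 log units; within the scatter).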

Compound 3, half-maximal effective concentration: 530 nM
The estimate for compound 3 lay 3.8-fold (0.58 log units) above the measured number; the measured number falls inside the stated range.
By their numbers in this assay, from the lowest: compounds 3 and 2 (each within the scatter of the next); then compound 1.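

In this assay, thiophen-2-yl in place of pyridin-3-yl, on an aromatic carbon para to a large group, gives a 2.0-fold lower number from compound 2 to compound 3 (0.30 log units; within the scatter) and leaves the two compounds indistinguishable. In this one pair, a five-membered aromatic ring with sulfur therefore serves as well as a six-membered aromatic ring with nitrogen. No measurement at hand offers a reason for this result.

Among the compounds shown here, compound 1 differs from both in more than one place and gives no step to read. On these data alone, whether a plain phenyl ring or a pyridine carrying an amine would read the same at this position remains open.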